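A Second Benzyl on a Nitrated Scaffold

The source may hold more compounds than are shown below. What is called first, only, known or untested is meant among the compounds shown, and "the series" means these compounds.

Compounds measured in an ADME assay on L6 cells (Rattus norvegicus) for cytotoxicity; on this read-out lower numbers stand for stronger inhibition and higher numbers for weaker inhibition:
- Compound 1 `O=C(NN(c1ccccc1)c1ccccc1)c1cc([N+](=O)[O-])ccc1F`: 3200 nM
- Compound 2 `O=c1c2cc([N+](=O)[O-])ccc2[nH]n1Cc1ccccc1`: 234000 nM
- Compound 3 `O=c1c2cc([N+](=O)[O-])ccc2[nH]n1Cc1ccccn1`: 287000 nM

Compound 2 sits at the high end of these numbers, level within the scatter with compound 3, whereas compound 1 gives the far lower 3200 nM. The next compound to be tested, compound 4 `O=c1c2cc([N+](=O)[O-])ccc2n(Cc2ccccc2)n1Cc1ccccc1`, has benzyl in place of hydrogen on an aromatic nitrogen, the change from compound 2 being (benzyl in place of hydrogen on an aromatic nitrogen).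

Among the measured compounds shown here, no measured step covers this change directly. For the measured compounds named here, the one step available is a 1.2-fold higher number from compound 2 to compound 3 (0.09 log units; within the scatter), which lies within the scatter, but it only swaps the ring of the benzyl group already present and says little about adding a new group. Going by the values given here, the sole low number in this assay is the 3200 nM of compound 1, a structure quite unlike compound 2, so it offers only a weak hint of direction. On that slender basis, a moderate move towards lower numbers is expected, though a result close to compound 2 would not be surprising. The expected size of the change is a 5.9-fold lower number from compound 2 to compound 4 (0.77 log units; beyond the scatter). For compound 4 the estimated value is 40000 nM, with an expected range from 6000 nM to 200000 nM.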

Compound 4, half-maximal inhibitory concentration: 37300 nM
The estimate for compound 4 lay 1.1-fold (0.03 log units) above the measured number; the range from low to high includes it.
By their numbers in this assay, from the lowest: compound 1; then compound 4; then compounds 2 and 3 (each within the scatter of the next).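

In this assay the step to the second benzyl group is a 6.3-fold lower number from compound 2 to compound 4 (0.80 log units; beyond the scatter) and so, unlike the earlier step, it lies beyond the scatter, showing that this aromatic nitrogen, which carries only hydrogen in compound 2, accepts a benzyl group with a modest move towards stronger inhibition. The earlier step of a 1.2-fold higher number from compound 2 to compound 3 (0.09 log units; within the scatter) stayed within the scatter and altered only the ring of the benzyl group already present, leaving this nitrogen untouched, so the new result is the first sign among these closely related compounds that substitution at this place changes the read-out. Nothing measured here bears on why the number falls at this position.

The compounds shown leave open whether the move belongs to benzyl itself or would also follow from a methyl group, a longer chain or a chain ending in an amine or a carboxylic acid on the same nitrogen, and whether a pyridin-2-ylmethyl group there would behave as benzyl does. They also leave open what in the differently built compound 1 goes with its 3200 nM and whether any further group on the shared core could reach a number of that order.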